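Notes on the step from compound 2 to compound 4

The compounds below may be only part of what the source reports. "The series", "measured", "known", "first", "only" and "open" are said of these compounds alone.

Measured in an ADME assay on microsomes from liver (Homo sapiens) for metabolic stability; on this read-out higher numbers stand for a longer-lived compound and lower numbers for a shorter-lived compound:
- compound 1 (`CC(C)C(c1ccc(-c2ccc3cccc(F)c3c2)[nH]c1=O)C1NC(=O)NC1=O`): 0.578 h
- compound 2 (`CC(C)C(c1ccc(-c2ccc3cccc(F)c3c2)[nH]c1=O)C1SC(=O)NC1=O`): 1.87 h
- compound 3 (`CCC(/C=C1\OC(=O)NC1=O)(CC)c1ccc(-c2ccc3cc(F)cc(F)c3c2)[nH]c1=O`): > 3 h (a limit of the assay)

Of the two numeric values, compound 2 holds the higher one (1.87 h). Compound 3 gives only a limit (the limit of > 3 h in this assay, at which 1 of the 3 values shown sits).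

Compound 4 (`CC(C)C(CC1NC(=O)NC1=O)c1ccc(-c2ccc3cccc(F)c3c2)[nH]c1=O`) carries (2,5-dioxoimidazolidin-4-yl)methyl in place of 2,4-dioxo-1,3-thiazolidin-5-yl on a saturated chain carbon bound to an aromatic carbon and a saturated chain carbon. Among the measured compounds shown here, the one measured step bearing on this exchanges the same two rings in the opposite direction (a 3.2-fold higher number from compound 1 to compound 2 (0.51 log units; beyond the scatter)). For the measured compounds named here, no measured step covers the added methyl part. A modest fall of similar size in this assay is therefore expected, on the strength of that step from compound 1. The expected change is a single step (a 2.7-fold lower number from compound 2 to compound 4 (0.43 log units; beyond the scatter)). Compound 4 is estimated at 0.7 h (range 0.3 h to 1.7 h).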

Compound 4, half-life: 1.59 h
Beside the measured number, compound 4's estimate is 2.3-fold (0.36 log units) below it; measured number inside the range.
By their numbers in this assay, from the lowest: compound 1; then compounds 4 and 2 (each within the scatter of the next). At a limit, above all of these: compound 3.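

In this assay, the 2,5-dioxoimidazolidin-4-yl ring is not tied to the lower number: adding the methyl part gives a 2.8-fold higher number from compound 1 to compound 4 (0.44 log units; beyond the scatter). Exchanging 2,4-dioxo-1,3-thiazolidin-5-yl for (2,5-dioxoimidazolidin-4-yl)methyl gives a 1.2-fold lower number from compound 2 to compound 4 (0.07 log units; within the scatter), so this read-out does not separate the two groups at this position. The gain over compound 1 therefore does not require 2,4-dioxo-1,3-thiazolidin-5-yl.

Nothing measured here gives a cause for these steps. On these data alone, whether a longer chain bearing the same ring, or a carboxylic acid in its place, would hold this number remains open.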